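From phenyl to 2-methylphenyl: one small change, one open question

The source may report more compounds than this note shows. Statements on the series, on what has been measured and on what is new or still open speak of the compounds shown alone.

Measured in an ADME assay on THP-1 cells (Homo sapiens) for cytotoxicity, read by resazurin assay, with a stated time of 48 h; a lower number here means a stronger inhibitor, a higher number a weaker inhibitor:
- compound 1 `O=c1c(O)cccn1Cc1ccc(-c2ccccc2)cc1`: > 10 ug/mL (a limit)
- compound 2 `N#Cc1ccc(-c2ccc(Cn3cccc(O)c3=S)cc2)cc1`: > 10 ug/mL (a limit)
- compound 3 `N#Cc1cccc(-c2ccc(Cn3cccc(O)c3=O)cc2)c1`: > 10 ug/mL (a limit)

Compound 1 gives only a limit, > 10 ug/mL, and not an exact number. The same holds across the series: the limit of > 10 ug/mL in this assay, at which 3 of the 3 values shown sit. Compound 4 `Cc1ccccc1-c1ccc(Cn2cccc(O)c2=O)cc1` differs from compound 1 by one small edit: methyl in place of hydrogen on an aromatic carbon. That is methyl in place of hydrogen on an aromatic carbon. The closest measured change is a step that the two limits leave unreadable from compound 1 to compound 3, so it offers no size to carry over. No step beyond the usual scatter is expected, and no direction can be favoured. The expected step is a step that the limit leaves unreadable from compound 1 to compound 4. Compound 4 is estimated at 15 ug/mL, with an expected range of 8 ug/mL to 50 ug/mL.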

Compound 4, half-maximal inhibitory concentration: > 10 ug/mL
Compound 4 ended at the assay's limit; the forecaster's own chance of this, stated with the estimate: 85%; the middle value lies beyond the limit too.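

Going by these compounds alone, compound 1 and compound 4 each give only a limit, not an exact number, so no step between them can be read. The compounds shown leave open whether methyl in place of hydrogen changes cytotoxicity at all.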